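Trimethoxy for Chloro on the Anilino Nitrogen

The compounds below may be only part of what the source reports. "The series", "measured", "known", "first", "only" and "open" are said of these compounds alone.

Compound 1 `O=C(CSc1nc(Nc2ccccc2)c2ccccc2n1)Nc1ccccc1Cl`: 9610 nM
Compound 2 `O=C(CSc1nc(Nc2ccccc2)c2ccccc2n1)Nc1cccc(F)c1`: 6790 nM
Compound 3 `C=CC(=O)Nc1cccc(NC(=O)CSc2nc(Nc3cccc(Cl)c3)c3ccccc3n2)c1`: 9460 nM

All three were tested in a functional assay on NCI-H1975 cells (Homo sapiens) for inhibition, read by MTT assay, with a stated time of 72 h; on this read-out higher numbers stand for weaker inhibition and lower numbers for stronger inhibition. Compound 3 stands second highest of the three numbers shown; its nearest neighbour is compound 1, whose number lies within the scatter of that of compound 3, and the number of compound 2 also lies within the scatter of that of compound 3. Compound 4 `C=CC(=O)Nc1cccc(NC(=O)CSc2nc(Nc3cc(OC)c(OC)c(OC)c3)c3ccccc3n2)c1` has not yet been measured. It differs from compound 3 by 3,4,5-trimethoxyphenyl in place of 3-chlorophenyl on a nitrogen on an aromatic ring. Going by the values given here, the only measured step, a 1.4-fold lower number from compound 1 to compound 2 (0.15 log units; within the scatter), concerns the group on the amide-type nitrogen rather than the nitrogen on the aromatic ring, and it stayed within the scatter. Among the compounds with values here, no measured step addresses the place that is changed here, so nothing in the data points to a move in either direction. For compound 4 the expected step is therefore a 1.1-fold lower number from compound 3 to compound 4 (0.02 log units; within the scatter), within the scatter. The estimate for compound 4 in this assay is 9000 nM, with a range from 3000 nM to 27000 nM.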

Compound 4, half-maximal inhibitory concentration: > 50000 nM
Compound 4: no number, only a limit (the forecaster's own chance of this, stated with the estimate: 10%); middle value at least 5.5-fold (0.74 log units) from the limit.
By their numbers in this assay, from the lowest: compounds 2, 3 and 1 (each within the scatter of the next). At a limit, above all of these: compound 4.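

In this assay, the group on the nitrogen on an aromatic ring proves to matter: 3,4,5-trimethoxyphenyl in place of 3-chlorophenyl gives an at least 5.2-fold higher number from compound 3 to compound 4 (0.72 log units; beyond the scatter). Going by these compounds alone, the earlier step, a 1.4-fold lower number from compound 1 to compound 2 (0.15 log units; within the scatter), concerned the group on the amide-type nitrogen and stayed within the scatter, so this is the first change in the set that clearly separates two compounds, and it goes towards weaker inhibition. The result for compound 4 is a limit and not a number: the limit of > 50000 nM in this assay, at which 1 of the 4 values shown sits.

The single change removes the chlorine and brings in three methoxy groups together, so the compounds shown cannot tell which of these accounts for the step. They also leave open how a phenyl carrying a single methoxy group, an amine or a carboxylic acid would behave at this place.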